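The source may hold more compounds than are shown below. What is called first, only, known or untested is meant among the compounds shown, and "the series" means these compounds.

In a functional assay on KM12 cells (Homo sapiens) for inhibition, read by sulforhodamine B assay, with a stated time of 48 h (on this read-out higher numbers stand for weaker inhibition of growth and lower numbers for stronger inhibition of growth), compound 1 `COc1cc(-c2nn(-c3cccc(NC(=O)Nc4ccc(Cl)c(Cl)c4)c3)cc2-c2ccncc2)ccc1Cl` gives 811 nM, and compound 2 `O=C(Nc1cccc(-n2cc(-c3ccncc3)c(-c3ccc(Cl)c(O)c3)n2)c1)Nc1ccc(Cl)c(Cl)c1` gives 1010 nM, so the two lie within the scatter of each other. Compound 3 `COc1cc(-c2nn(-c3cccc(NC(=O)c4ccccc4)c3)cc2-c2ccncc2)ccc1Cl` differs from compound 1 in another way: phenyl in place of (3,4-dichlorophenyl)amino on a carbonyl carbon. For the measured compounds named here, the only measured step, a 1.2-fold higher number from compound 1 to compound 2 (0.10 log units; within the scatter), involves a different and much smaller change, so it offers no direct guide here. Going by the values given here, with no measured precedent, a moderate move towards weaker inhibition of growth is expected in this assay, though this remains uncertain. The estimated step is a 3.7-fold higher number from compound 1 to compound 3 (0.57 log units; beyond the scatter). Compound 3 is estimated at 3000 nM, with an expected range of 900 nM to 10000 nM.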

Compound 3, concentration for 50% growth inhibition: 556 nM
Compound 3: the middle estimate sits 5.4-fold (0.73 log units) above what was measured, outside the stated range (below it).
By their numbers in this assay, from the lowest: compounds 3, 1 and 2 (each within the scatter of the next).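

Putting phenyl in place of (3,4-dichlorophenyl)amino on the carbonyl carbon gives a 1.5-fold lower number from compound 1 to compound 3 (0.16 log units; within the scatter) in this assay. The two compounds therefore cannot be told apart here, so neither the two chlorine atoms nor the hydrogen-bond donor that leave with this group is needed to keep this level of growth inhibition. No measurement at hand explains this result.

On these data alone, it remains open whether this carbonyl carbon needs an aromatic ring at all. A methyl group or a morpholine ring there would test this.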